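The compounds below may be only part of what the source reports. "The series", "measured", "known", "first", "only" and "open" are said of these compounds alone.

Measured in an ADME assay on Vero cells (Chlorocebus sabaeus) for cytotoxicity, read by MTT assay, with a stated time of 72 h; on this read-out higher numbers stand for weaker inhibition and lower numbers for stronger inhibition:

compound 1 `CC(=O)N1N=C(c2ccc(-n3c(C)ccc3C)cc2)OC1c1ccc(Br)cc1`: 195000 nM
compound 2 `O=C(NNC(=O)c1cccc([N+](=O)[O-])c1)c1ccc(-n2cccc2)cc1`: 195000 nM
compound 3 `Cc1ccc(C)n1-c1ccc(-c2nnc(S)o2)cc1`: 261000 nM

Compound 1 and compound 2 read the same at the digits shown in this assay, and compound 3 differs from compound 1 only within the scatter, so the three numbers cannot be told apart. The shared core of compound 1 carries a bromo group on a six-membered aromatic ring of carbon only, para to a large group. Compound 4 `CC(=O)N1N=C(c2ccc(-n3c(C)ccc3C)cc2)OC1c1ccc(N(C)C)cc1` differs from compound 1 in this single place: dimethylamino in place of bromo on an aromatic carbon. Among the measured compounds shown here, no pair of measured compounds differing in one place exists here. With three indistinguishable numbers as the only background, the step of a 1.0-fold higher number from compound 1 to compound 4 (0.01 log units; within the scatter) is expected to stay within the scatter, with no direction favoured. Compound 4 is expected to give 200000 nM in this assay, within 100000 nM to 400000 nM.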

Compound 4, half-maximal inhibitory concentration: 175000 nM
Beside the measured number, compound 4's estimate is 1.1-fold (0.06 log units) above it; low and high end bracket the measured number.
By their numbers in this assay, from the lowest: compounds 4, 1, 2 and 3 (each within the scatter of the next).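

In this assay, among the compounds shown here, dimethylamino in place of bromo on the aromatic carbon gives a 1.1-fold lower number from compound 1 to compound 4 (0.05 log units; within the scatter) as the first single-place step. At this position, para to a large group, the exchange of a halogen for an amine therefore leaves the number within the scatter. No measurement on hand offers an explanation for this result.

From the compounds shown here alone, whether a carboxylic acid or a longer chain at this position would move the number beyond the scatter remains open. So does the effect of changes elsewhere on the shared core.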